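The compounds below may be only part of what the source reports. "The series", "measured", "known", "first", "only" and "open" are said of these compounds alone.

Measured in an ADME assay on CEMx174 cells (Homo sapiens) for cytotoxicity; on this read-out higher numbers stand for lower toxicity in this test and lower numbers for higher toxicity in this test:
Compound 1 `CCC1=C(C(=O)OCC2CCCCC2)C(c2ccc(O)cc2)NC(=O)N1`: > 10000 nM (a limit)
Compound 2 `CCC1=C(C(=O)OCC2CCCCC2)C(c2cccc([N+](=O)[O-])c2)NC(=O)N1`: > 10000 nM (a limit)

Compound 2 stands at the limit of the assay, so its entry is not a number. Both measured compounds sit at this same limit (the limit of > 10000 nM in this assay, at which 2 of the 2 values shown sit). Among the compounds with values here, the only measured step, a step that the two limits leave unreadable from compound 1 to compound 2, gives no size to carry forward.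

Compound 3 `CCC1=C(C(=O)OCC2CCCCC2)C(c2ccc([N+](=O)[O-])cc2)NC(=O)N1` has 4-nitrophenyl in place of 3-nitrophenyl on a saturated ring carbon. With the measured compounds resting at the limit (the limit of > 10000 nM in this assay, at which 2 of the 2 values shown sit), no step beyond the scatter is expected in this assay, and neither direction is favoured. The expected change is a step that the limit leaves unreadable from compound 2 to compound 3. For compound 3 the estimate is 15000 nM, with an expected range of 8000 nM to 40000 nM. A report as a limit is the likeliest outcome.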

Compound 3, half-maximal cytotoxic concentration: > 10000 nM
Compound 3 ended at the assay's limit; the forecaster's own chance of this, stated with the estimate: 90%; the middle value does not contradict the limit.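

In this assay compound 3 gives > 10000 nM, a limit and not a number. No step from compound 1 or compound 2 to compound 3 can be read: the limit of > 10000 nM in this assay, at which 3 of the 3 values shown sit.

The compounds shown leave open whether compound 1, compound 2 and compound 3 differ at all in this assay.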